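Thiosemicarbazone series: nitro substitution on compound 2

This account rests on a few compounds, and the source may have more. Where it says the series, first, only, none or still open, it means among the compounds named here.

Measured so far:
compound 1 `CC1=CC[C@H](C(C)(C)NC(=S)N/N=C/c2ccccc2O)CC1`: 10900 nM
compound 2 `CC1=CC[C@H](C(C)(C)NC(=S)N/N=C(\C)c2ccccc2)CC1`: 29500 nM

In a functional assay on HT-29 cells (Homo sapiens) for inhibition, read by sulforhodamine B assay, with a stated time of 48 h (on this read-out lower numbers stand for stronger inhibition of growth and higher numbers for weaker inhibition of growth), compound 1 gives 10900 nM and compound 2 gives 29500 nM. Compound 2 has the highest number of the two, and its gap to compound 1 lies beyond the scatter. Compound 3 `CC1=CC[C@H](C(C)(C)NC(=S)N/N=C(\C)c2ccc([N+](=O)[O-])cc2)CC1` is not yet measured. It differs from compound 2 by nitro in place of hydrogen on an aromatic carbon, para to a large group. Going by the values given here, no measured pair shows this change, so no direction is set; the expected step of a 1.2-fold lower number from compound 2 to compound 3 (0.07 log units; within the scatter) is not beyond the scatter. Compound 3 is expected to give 25000 nM, within 8000 nM to 80000 nM.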

Compound 3, concentration for 50% growth inhibition: 29900 nM
Beside the measured number, compound 3's estimate is 1.2-fold (0.08 log units) below it, and the stated range covers the measured number.
By their numbers in this assay, from the lowest: compound 1; then compounds 2 and 3 (each within the scatter of the next).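

In this assay, nitro in place of hydrogen on an aromatic carbon, para to a large group, gives a 1.0-fold higher number from compound 2 to compound 3 (0.01 log units; within the scatter) and so leaves compound 3 level with compound 2. This carbon of compound 2 therefore carries a group of 3 heavy atoms with no step beyond the scatter. No supporting measurement is available to account for this result. Going by these compounds, whether an amine, a carboxylic acid or a methoxy group on this same carbon would also leave the number in place remains open.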